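The compounds below may be only part of what the source reports. "The series", "measured", "known", "first", "only" and "open" are said of these compounds alone.

The question here is cytotoxicity in a functional assay on HeLa cells (Homo sapiens) for cytotoxicity, read by MTT assay, with a stated time of 72 h; on this read-out higher numbers stand for weaker inhibition and lower numbers for stronger inhibition. Compound 1 `Cc1cc(C)nc(SCc2cc(=O)c3cc(Cl)ccc3o2)n1` is known there only as a limit: in this assay compound 1 gives > 25000 nM, a limit of the assay and not a number. Compound 3 `O=c1cc(CSc2nc3ccccc3s2)oc2ccc(Cl)cc12` sits at a limit as well: in this assay compound 3 gives > 25000 nM, again a limit and not a number. Compound 2 `O=c1c(CSc2cc(=O)c3ccccc3s2)coc2ccccc12` alone yields a number, and in this assay compound 2 gives 2600 nM. So compound 1 stands together with compound 3 at the limit of > 25000 nM in this assay, at which 2 of the 3 values shown sit, while compound 2 stands apart with a measured value.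

Compound 4 `Cc1cc(C)nc(SCc2cc(=O)c3ccccc3o2)n1` has not been measured. It differs from compound 1 in one place: hydrogen in place of chloro on an aromatic carbon. Going by the values given here, no pair of measured compounds differing in one place exists here, so nothing shows what this change does. Compound 4 is expected to stay close to compound 1, with the estimated step that the limit leaves unreadable from compound 1 to compound 4 lying within the scatter. Compound 4 is estimated at 30000 nM, within a range from 8000 nM to 100000 nM, and most likely reported as a limit again.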

Compound 4, half-maximal inhibitory concentration: > 25000 nM
Compound 4: a limit, no number (the forecaster's own chance of this, stated with the estimate: 70%); the middle value does not contradict the limit.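

No step can be read from compound 1 to compound 4, as both are known in this assay only as a limit and not as a number: the limit of > 25000 nM in this assay, at which 3 of the 4 values shown sit.

The compounds shown leave open what hydrogen in place of chloro on an aromatic carbon does to cytotoxicity.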